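Adding a second methoxy to compound 2

The compounds below may be only part of what the source reports. "The series", "measured", "known", "first", "only" and "open" are said of these compounds alone.

Compound 2 `COc1ccc(-c2cc(C(=O)Nc3nc4ccc(F)cc4s3)nc3cc(-c4ccccc4)nn23)cc1` gives 31400 nM in a functional assay on DU-145 cells (Homo sapiens) for cytotoxicity, read by MTT assay, with a stated time of 48 h (a higher number here means a weaker inhibitor, a lower number a stronger inhibitor), the highest of the two numbers in hand. Its nearest neighbour, compound 1 `COc1ccc(-c2cc(C(=O)Nc3nc4ccc(Cl)cc4s3)nc3cc(-c4ccccc4)nn23)cc1OC`, gives 9330 nM in this assay, a gap beyond the scatter; the two differ in more than one place. Compound 3 `COc1ccc(-c2cc(C(=O)Nc3nc4ccc(F)cc4s3)nc3cc(-c4ccccc4)nn23)cc1OC` carries methoxy in place of hydrogen on an aromatic carbon, so 4-methoxyphenyl becomes 3,4-dimethoxyphenyl, the pattern compound 1 shares. Within the data shown here, no single-change step is known; a modest lowering of the number is expected, since compound 1 gives 9330 nM. Compound 3 is estimated at 15000 nM, within 5000 nM to 40000 nM, a step of a 2.1-fold lower number from compound 2 to compound 3 (0.32 log units; beyond the scatter).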

Compound 3, half-maximal inhibitory concentration: 18600 nM
For compound 3 the middle estimate is 1.2-fold (0.09 log units) below the measured one; low and high end bracket the measured number.
By their numbers in this assay, from the lowest: compounds 1, 3 and 2 (each within the scatter of the next, the first and the last beyond it).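

In this assay, among these compounds, the first single-change reading at this position gives (a 1.7-fold lower number from compound 2 to compound 3 (0.23 log units; within the scatter)), so methoxy in place of hydrogen, taking 4-methoxyphenyl to 3,4-dimethoxyphenyl, is not resolved from the scatter. The halogen change on the other side of the series reads (a 2.0-fold higher number from compound 1 to compound 3 (0.30 log units; within the scatter)) and is likewise not resolved. Nothing in hand bears on the reason for either step. 

Open, as far as these compounds go, is whether a different group at this aromatic carbon, such as an amine or a carboxylic acid, would move the number beyond the scatter. From the compounds shown here alone, the effect of methoxy in place of hydrogen with chloro on the other ring also remains open.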